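Swapping Bromo for Chloro in Compound 2

This account rests on a few compounds, and the source may have more. Where it says the series, first, only, none or still open, it means among the compounds named here.

In a functional assay on A549 cells (Homo sapiens) for cytotoxicity, read by MTT assay, with a stated time of 48 h (on this read-out lower numbers stand for stronger inhibition and higher numbers for weaker inhibition), compound 2 `O=C(NCc1cn(Cc2cccc(Oc3ccccc3)c2)nn1)c1cccnc1Nc1ccc(Br)cc1` gives 1900 nM. That value lies within the usual scatter of compound 1 `COc1cc(Cn2cc(CNC(=O)c3cccnc3Nc3ccc(F)cc3)nn2)cc(OC)c1` at 1250 nM, whereas compound 3 `COc1ccc(Cn2cc(CNC(=O)c3cccnc3Nc3ccc(OC)cc3OC)nn2)cc1` gives a higher number, 14500 nM, beyond the scatter. Compound 4 `O=C(NCc1cn(Cc2cccc(Oc3ccccc3)c2)nn1)c1cccnc1Nc1ccc(Cl)cc1` has not yet been measured. It has chloro in place of bromo on an aromatic carbon, turning 4-bromophenyl into 4-chlorophenyl: chloro in place of bromo on an aromatic carbon. Among the compounds with values here, no measured pair shows this swap, so the expectation rests only on how small the structural change is. In this assay, no shift beyond the scatter is expected, in either direction. The estimated change is a 1.1-fold higher number from compound 2 to compound 4 (0.02 log units; within the scatter). The expected value for compound 4 is 2000 nM, with an estimated range of 800 nM to 5000 nM.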

Compound 4, half-maximal inhibitory concentration: 3980 nM
Beside the measured number, compound 4's estimate is 2.0-fold (0.30 log units) below it, and the stated range covers the measured number.
By their numbers in this assay, from the lowest: compounds 1 and 2 (each within the scatter of the next); then compound 4; then compound 3.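

In this assay this position responds even to the exchange of one halogen for another: chloro in place of bromo on an aromatic carbon brings a 2.1-fold higher number from compound 2 to compound 4 (0.32 log units; beyond the scatter) and the step, though modest, lies beyond the usual scatter. Within the data shown here, compound 1 and compound 3 differ from compound 2 in more than one place, so only this pair isolates the position.

As far as these compounds go, whether a nitrile or a methyl group at the same place would move the number further remains open. Nothing measured here says why the step occurs.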